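The compounds below may be only part of what the source reports. "The series", "measured", "known", "first", "only" and "open" are said of these compounds alone.

Working notes on the series. Three compounds are measured: compound 1 `Cc1nn2c(-c3nc4c(C)c(C)ccc4[nH]3)c(-c3ccccc3)nc2s1`, compound 2 `Cc1ccc2[nH]c(-c3c(-c4ccc(F)cc4)nc4sc(C)nn34)nc2c1` and compound 3 `Cc1ccc(-c2nc3sc(C)nn3c2-c2nc3c(C)c(C)ccc3[nH]2)cc1`. In a functional assay on A-375 cells (Homo sapiens) for antiproliferative activity, read by MTT assay (on this read-out lower numbers stand for stronger inhibition and higher numbers for weaker inhibition), compound 1 gives 22900 nM. In this assay compound 3 gives 11400 nM, and compound 2 gives 7700 nM. Compound 2 holds the lowest number of the three, but its gap to compound 3 lies within the scatter, so no order between compound 2 and compound 3 can be read; its gap to compound 1 lies beyond the scatter. How the core of compound 2 differs from that of compound 1 is not broken down here.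

The change from compound 1 to compound 3 is methyl in place of hydrogen on an aromatic carbon. It gave a 2.0-fold lower number from compound 1 to compound 3 (0.30 log units; within the scatter).

Compound 4 `Cc1nn2c(-c3nc4cc(C)c(C)cc4[nH]3)c(-c3ccc(F)cc3)nc2s1` is not yet measured. It differs from compound 2 by methyl in place of hydrogen on an aromatic carbon. Going by the values given here, this is the same kind of change as the one from compound 1 to compound 3, not the same: there the methyl sits para to a large group on a six-membered ring of carbon only, here it sits on a ring that is part of a fused system of two rings, ortho to a methyl group, meta to a fused ring and para to a fused ring. Among the compounds with values here, only one measured instance of this kind of change exists, and it lies within the scatter.

Within the data shown here, the step expected from this kind of change is a 1.4-fold lower number from compound 2 to compound 4 (0.15 log units; within the scatter), set beside the measured 2.0-fold lower number from compound 1 to compound 3 (0.30 log units; within the scatter), since the only anchor is the step from compound 1 to compound 3 and the surroundings of the place differ. For compound 4 the number expected in this assay is 5500 nM, between 2500 nM and 12000 nM.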

Compound 4, half-maximal inhibitory concentration: 7600 nM
Compound 4: the middle estimate sits 1.4-fold (0.14 log units) below what was measured, within the range that was stated.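

In this assay, methyl in place of hydrogen on an aromatic carbon gives a 1.0-fold lower number from compound 2 to compound 4 (0.01 log units; within the scatter), so no effect of this change can be read on this core either. Set side by side, the two instances of the change cannot be told apart, and nothing here indicates that the size of the step depends on the core: the same change on two cores in this assay, a 2.0-fold lower number (0.30 log units; within the scatter) from compound 1 to compound 3 and a 1.0-fold lower number (0.01 log units; within the scatter) from compound 2 to compound 4, 2.0-fold (0.30 log units) apart, within the scatter of two such steps. This does not show that the change has no effect, nor that it carries from core to core with a fixed size, since there are only two instances, neither step rises above the scatter, and the surroundings of the methyl differ between them; the agreement is between two steps that are each too small to read.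

The compounds shown leave open whether any group at this place would give a step beyond the scatter, for instance a longer chain such as propyl, an amine or a carboxylic acid in place of the methyl. They also leave open whether methyl in place of hydrogen at other places on these cores, or on other cores of the series, would give a step that can be read in this assay.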